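Aza Variation of the Urea Aryl Group in Compound 2

The source may report more compounds than this note shows. Statements on the series, on what has been measured and on what is new or still open speak of the compounds shown alone.

Measured so far:
compound 1, `O=C(Nc1cccc2cn[nH]c12)N1CCN(Cc2cccc(Oc3ccc(Cl)cc3)c2)CC1`: in an assay on isolated protein for inhibition of Fatty-acid amide hydrolase 1 (Rattus norvegicus), with a stated time of 60 min (a higher number here means a weaker inhibitor, a lower number a stronger inhibitor), compound 1 gives 6000 nM.
compound 2, `O=C(Nc1noc2ccccc12)N1CCN(Cc2cccc(Oc3ccc(Cl)cc3)c2)CC1`: in this assay compound 2 gives 8.1 nM.

For the measured compounds named here, compound 2 stands as the lower of the two numbers; the only comparison is compound 1, and the step of a 740-fold lower number from compound 1 to compound 2 (2.87 log units; beyond the scatter) separates them. That step exchanged one bicyclic group for another on the amide-type nitrogen, so the number moved greatly when this group was changed. Compound 3, `O=C(Nc1noc2cnccc12)N1CCN(Cc2cccc(Oc3ccc(Cl)cc3)c2)CC1`, keeps the framework of compound 2 and alters it as follows: a group of 9 heavy atoms (6 carbon, 2 nitrogen, 1 oxygen; one five-membered aromatic ring with 2 hetero atoms, one six-membered aromatic ring with 1 hetero atom) in place of a group of 9 heavy atoms (7 carbon, 1 nitrogen, 1 oxygen; one five-membered aromatic ring with 2 hetero atoms, one six-membered aromatic ring of carbon only), on an amide-type nitrogen. Going by the values given here, no measured step exchanges a carbon for a nitrogen within the six-membered ring, and the five-membered aromatic ring with 2 hetero atoms of compound 2 is retained, so the earlier step bears on the present one only by showing that the group on the amide-type nitrogen can shift the number strongly. Given that, a modest step is expected, most likely toward a somewhat higher number, a 1.9-fold higher number from compound 2 to compound 3 (0.27 log units; within the scatter). Compound 3 is therefore estimated at 15 nM, with a range from 3 nM to 80 nM.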

Compound 3, half-maximal inhibitory concentration: 0.7 nM
Compound 3: middle estimate off by 21-fold (1.33 log units), on the high side, outside the stated range (below it).
By their numbers in this assay, from the lowest: compound 3; then compound 2; then compound 1.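

Working from this assay, the step of a 12-fold lower number from compound 2 to compound 3 (1.06 log units; beyond the scatter) shows that the six-membered ring of the group on the amide-type nitrogen is itself sensitive: a single ring carbon exchanged for nitrogen, with the five-membered aromatic ring retained, moves the number beyond the scatter. For the compounds shown here, the earlier compounds showed only that the number responds when the hetero atoms of the five-membered ring differ, whereas the step of an 8600-fold lower number from compound 1 to compound 3 (3.93 log units; beyond the scatter) now sets the span reached by this group alone with the rest of the molecule unchanged, and both exchanges seen so far at this place that lead toward compound 3 lower the number. No measurement at hand accounts for the gain from the ring nitrogen.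

Still open, from the compounds shown here alone, is whether the gain depends on where the nitrogen sits in the six-membered aromatic ring with 1 hetero atom, and whether a second ring nitrogen, a fluorine or a methoxy group on that ring would lower the number further or raise it. Also open, going by these compounds, is whether the gain carries over when the chlorine of the shared core gives way to a nitrile.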